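Swapping Methoxy for Chloro on a Cinnamamide Inhibitor

The source may report more compounds than this note shows. Statements on the series, on what has been measured and on what is new or still open speak of the compounds shown alone.

Measured compounds:
- compound 1, `COc1cccc(/C=C/C(=O)Nc2nc3ccccc3c(=O)s2)c1`: 470 nM
- compound 2, `O=C(CCCc1ccccc1)Nc1nc2sccc2c(=O)s1`: 69.7 nM

Of the compounds shown here, two have been measured in an in vitro assay on cells for inhibition of Amine oxidase [flavin-containing] B (Homo sapiens), read by fluorescence and Amplex Red, with stated times of 30 min and 45 min; on this read-out higher numbers stand for weaker inhibition and lower numbers for stronger inhibition. Compound 1 gives 470 nM in this assay, the higher of the two numbers. Compound 2 differs from compound 1 in several places. In this assay compound 2 gives 69.7 nM, and the gap between the two numbers lies beyond the usual scatter. The two compounds differ in several places at once. Among the measured compounds shown here, no single step between them can be read off.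

Compound 3, `O=C(/C=C/c1cccc(Cl)c1)Nc1nc2ccccc2c(=O)s1`, has not yet been measured. It differs from compound 1 in one place: chloro in place of methoxy on an aromatic carbon. For the measured compounds named here, no measured pair shows what this change does on the shared core, so any expectation rests on compound 1 alone. The step from compound 1 to compound 3 is expected to be small, probably toward a lower number but possibly within the scatter, giving a 1.7-fold lower number from compound 1 to compound 3 (0.22 log units; within the scatter). Compound 3 is therefore estimated at 280 nM in this assay, within a range from 90 nM to 900 nM.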

Compound 3, half-maximal inhibitory concentration: 93.3 nM
Compound 3: middle estimate off by 3.0-fold (0.48 log units), on the high side; low and high end bracket the measured number.
By their numbers in this assay, from the lowest: compounds 2 and 3 (each within the scatter of the next); then compound 1.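

In this assay, among the compounds shown here, putting chloro in place of methoxy on an aromatic carbon gives a 5.0-fold lower number from compound 1 to compound 3 (0.70 log units; beyond the scatter), and this is the first single change that can be read on the shared core. It shows that this place on the six-membered aromatic ring, meta to a large group, is not indifferent to what sits there: going from 3-methoxyphenyl to 3-chlorophenyl moves the number beyond the usual scatter, toward stronger inhibition. The swap takes away two heavy atoms with one hydrogen-bond acceptor and brings in one chlorine atom with no hydrogen-bond acceptor, but nothing at hand says which part of this exchange accounts for the lower number.

The compounds shown leave open whether the gain belongs to chloro itself or simply to the loss of methoxy, which a plain hydrogen, a fluoro or a methyl at the same place could help to separate. They also leave open how an amine or a carboxylic acid at this place would read, and whether the same swap would give a similar step on a different core.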